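A Dichlorothiophene Enters the Series

The compounds below may be only part of what the source reports. "The series", "measured", "known", "first", "only" and "open" are said of these compounds alone.

Compound 1 (`Cc1cc(C(=O)/C=C/c2cc3cccc(C)c3nc2Cl)c(C)s1`), compound 2 (`Cc1ccc2cc(/C=C/C(=O)c3ccc(Cl)s3)c(Cl)nc2c1`) and compound 3 (`Cc1ccc2nc(Cl)c(/C=C/C(=O)c3sccc3Cl)cc2c1`) were examined in a functional assay on HUVEC cells (Homo sapiens), read by BrdU incorporation, with a stated time of 72 h (a lower number here means a stronger inhibitor, a higher number a weaker inhibitor), but only two of them yielded a number. For compound 1 the entry reads "not determined" (no result reported) and nothing can be said about its activity. Compound 2 gives 49.5 nM and compound 3 gives 37.5 nM in this test. Compound 3 therefore stands level with compound 2 within the scatter, and one further compound in the set has no number to compare.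

Compound 4 (`Cc1ccc2nc(Cl)c(/C=C/C(=O)c3cc(Cl)sc3Cl)cc2c1`) has not yet been measured. It carries 2,5-dichlorothiophen-3-yl in place of the 3-chlorothiophen-2-yl of compound 3 on a carbonyl carbon (2,5-dichlorothiophen-3-yl in place of 3-chlorothiophen-2-yl on a carbonyl carbon). Going by the values given here, no step between measured compounds shows what such an exchange does, so the data offer no direct guide. Among the compounds with values here, with compound 2 at 49.5 nM and compound 3 at 37.5 nM as the only numbers in hand, a large shift in this assay is not the expectation, and the direction remains uncertain. The estimated change is a 1.3-fold higher number from compound 3 to compound 4 (0.12 log units; within the scatter) and is not expected to go beyond the scatter. Compound 4 is expected at 50 nM with an estimated range from 15 nM to 160 nM in this assay when it is tested.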

Compound 4, half-maximal inhibitory concentration: 26.2 nM
The estimate for compound 4 lay 1.9-fold (0.28 log units) above the measured number, and the stated range covers the measured number.
By their numbers in this assay, from the lowest: compounds 4, 3 and 2 (each within the scatter of the next).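

In this assay, going by these compounds alone, replacing 3-chlorothiophen-2-yl with 2,5-dichlorothiophen-3-yl on a carbonyl carbon gives a 1.4-fold lower number from compound 3 to compound 4 (0.16 log units; within the scatter), the first step in this set that can be read between two measured compounds differing in one place. This place on the carbonyl carbon therefore tolerates both a second chlorine and a shift in the point of attachment of the thiophene, with no change beyond the scatter, and the two groups cannot be told apart in this test. Nothing at hand bears on the reason for this result.

From the compounds shown here alone, whether a plain thiophen-3-yl, a phenyl ring or a thiophene carrying an amine in place of chlorine would keep a number of this order on the same carbonyl carbon remains open, as does the question of what each of the two chlorines of 2,5-dichlorothiophen-3-yl contributes on its own. Going by these compounds, it is also open whether the same exchange would read alike on the core of compound 1 or the core of compound 2, and how these groups would compare in any test other than this assay.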